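This account rests on a few compounds, and the source may have more. Where it says the series, first, only, none or still open, it means among the compounds named here.

Measured compounds:
- compound 1, `CCCCCc1ccc(C#Cc2cn(CCC(COC(C)=O)COC(C)=O)c(=O)n(C(=O)c3ccccc3)c2=O)cc1`, 100 nM
- compound 2, `CC(=O)OCC(CCn1cc(C#CCc2ccccc2)c(=O)n(C(=O)c2ccccc2)c1=O)COC(C)=O`, 26800 nM

In a functional assay on MCF7 cells (Homo sapiens) for antiproliferative activity, read by MTT assay, with a stated time of 72 h (a higher number here means a weaker inhibitor, a lower number a stronger inhibitor), compound 2 stands at the higher of the two numbers, with compound 1 the nearest neighbour below it by a 270-fold higher number from compound 1 to compound 2 (2.43 log units; beyond the scatter), a step that exchanges the 4-pentylphenyl of compound 1 for the benzyl of compound 2 on the triple-bonded carbon.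

Compound 3, `CCCCCCCCC#Cc1cn(CCC(COC(C)=O)COC(C)=O)c(=O)n(C(=O)c2ccccc2)c1=O`, is not yet measured. Against compound 2 it shows (heptyl in place of phenyl on a saturated chain carbon bound to a triple-bonded carbon). Among the measured compounds shown here, the only measured step, a 270-fold higher number from compound 1 to compound 2 (2.43 log units; beyond the scatter), concerns a different exchange at the same triple-bonded carbon and therefore bears only loosely on this one; no measured pair separates a phenyl from a heptyl at this position. What the two numbers do show is that the group beyond the triple bond can move the result far beyond the scatter. The step to compound 3 is therefore expected to be sizeable, estimated as an 8.9-fold lower number from compound 2 to compound 3 (0.95 log units; beyond the scatter), though its direction is the least certain part of the estimate.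

Compound 3 is estimated in this assay at 3000 nM, within a range from 300 nM to 30000 nM.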

Compound 3, half-maximal inhibitory concentration: 28900 nM
For compound 3 the middle estimate is 9.6-fold (0.98 log units) below the measured one; measured number inside the range.
By their numbers in this assay, from the lowest: compound 1; then compounds 2 and 3 (each within the scatter of the next).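

In this assay, the exchange of phenyl for heptyl on a saturated chain carbon bound to a triple-bonded carbon gives a 1.1-fold higher number from compound 2 to compound 3 (0.03 log units; within the scatter), so this assay does not tell the ring-bearing benzyl group of compound 2 from the open octyl chain of compound 3. The other comparison gives a 290-fold higher number from compound 1 to compound 3 (2.46 log units; beyond the scatter), which shows that a long carbon chain on the triple-bonded carbon does not by itself bring the number close to that of compound 1; among these three compounds, only the 4-pentylphenyl group goes with a low number. No measurement available here explains why these groups compare as they do.

The 4-pentylphenyl group combines a ring on the triple-bonded carbon with a chain on that ring, and these compounds cannot show which part matters, or whether both do. A plain phenyl on the triple-bonded carbon, or a phenyl carrying a shorter propyl chain or a longer octyl chain, would separate these two parts of the group.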